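This account rests on a few compounds, and the source may have more. Where it says the series, first, only, none or still open, it means among the compounds named here.

Measured in a functional assay on MCF7 cells (Homo sapiens) for cytotoxicity, read by MTT assay, with a stated time of 72 h; a higher number here means a weaker inhibitor, a lower number a stronger inhibitor:
- Compound 1 `COc1ccc(/C=C2\CCC/C(=C\c3cccc(Cl)c3)C2=O)cc1OC`: 6000 nM
- Compound 2 `COc1cccc(/C=C2\CCC/C(=C\c3ccc(OC)c(OC)c3)C2=O)c1`: 4600 nM

Within the data shown here, only these two compounds have numbers so far, and the numbers cannot be told apart. Among the measured compounds shown here, compound 2, at 4600 nM, therefore stands level with the only other measured value.

The next compound is compound 3 `COc1ccc(/C=C2\CCC/C(=C\c3cccc(Cl)c3Cl)C2=O)cc1OC`. The move to it is 2,3-dichlorophenyl in place of 3-methoxyphenyl on a double-bonded chain carbon bound to a double-bonded ring carbon.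

For the measured compounds named here, only one measured step bears on this, and only in part. It also trades methoxy and chloro on an aromatic carbon, and it came out as a 1.3-fold lower number from compound 1 to compound 2 (0.12 log units; within the scatter). That small step gives no reason to expect a real shift in this assay, so no step beyond the scatter is expected. Going by the values given here, no measured compound carries 2,3-dichlorophenyl, however, so the range has to stay wide.

The expected step is a 1.2-fold lower number from compound 2 to compound 3 (0.06 log units; within the scatter).

For compound 3 the estimated value is 4000 nM, with an expected range from 1300 nM to 12000 nM.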

Compound 3, half-maximal inhibitory concentration: 14300 nM
Estimate against measurement, compound 3: 3.6-fold (0.55 log units) below; the measured number lies above the stated range.
By their numbers in this assay, from the lowest: compounds 2 and 1 (each within the scatter of the next); then compound 3.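

In this assay, the earlier swap of methoxy for chloro on an aromatic carbon left the number within the scatter, but this aromatic ring on the double-bonded chain carbon does respond to change. Among these compounds, putting 2,3-dichlorophenyl in place of 3-methoxyphenyl gives a 3.1-fold higher number from compound 2 to compound 3 (0.49 log units; beyond the scatter), and the single change of chloro in place of hydrogen on an aromatic carbon gives a 2.4-fold higher number from compound 1 to compound 3 (0.38 log units; beyond the scatter); both steps are modest, but both point towards a weaker inhibitor, so a further chloro on this ring did not help in these compounds. Nothing given here accounts for why this extra chloro raises the number.

From the compounds shown here alone, all three compounds keep the same dimethoxy-substituted aromatic ring on the other side of the shared core, so it remains open how far changes there would move the number. It is also open whether a hydroxy group or an amine on the ring that varies here would give a real drop in the number, which none of the three compounds shown achieves.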